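The source may report more compounds than this note shows. Statements on the series, on what has been measured and on what is new or still open speak of the compounds shown alone.

Measured so far:
- compound 1, `COc1ccc2c(c1F)C(=O)N(C[C@@]1(c3cc4nc(N5CCN(C)CC5)ccc4o3)NC(=O)N(COC(=O)C(C)(C)C)C1=O)C2`: 934 ng.h/mL
- compound 2, `COc1ccc2c(c1)C(=O)N(C[C@@]1(c3cc4nc(N5CCNCC5)ccc4o3)NC(=O)N(COC(=O)C(C)(C)C)C1=O)C2`: "not determined" (no result reported)
- compound 3, `COc1ccc2c(c1)C(=O)N(C[C@@]1(c3cc4nc(N5CCCNC5=O)ccc4o3)NC(=O)N(COC(=O)C(C)(C)C)C1=O)C2`: "not determined" (no result reported)

These three share one core and differ only in the group attached to the aromatic ring next to the ring nitrogen. In an ADME assay on the whole organism for pharmacokinetics, with Rattus norvegicus as the target, read by LC-MS, at a dose of 10 mg/kg by the oral route (a higher number here means more compound in the circulation at the dose given, a lower number less compound in the circulation), compound 1 gives 934 ng.h/mL. For the measured compounds named here, compound 3 stands without a number in this assay, and compound 2 is in the same position, so no step between measured compounds can be drawn and compound 1 is the only anchor.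

Compound 4, `COc1ccc2c(c1)C(=O)N(C[C@@]1(c3cc4nc(N5CC[C@@H](O)C5)ccc4o3)NC(=O)N(COC(=O)C(C)(C)C)C1=O)C2`, carries a group of 6 heavy atoms (4 carbon, 1 nitrogen, 1 oxygen; one five-membered non-aromatic ring with 1 hetero atom) in place of a group of 7 heavy atoms (4 carbon, 2 nitrogen, 1 oxygen; one six-membered non-aromatic ring with 2 hetero atoms), on an aromatic carbon. Going by the values given here, there is no measured step to lean on for the size or direction of this change. Among the compounds with values here, since compound 1 is the sole number available and compound 4 shares its core apart from the fluorine and the replaced group, the expectation is a value of the same order, with wide uncertainty in both directions that covers a step of any size beyond the scatter.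

Compound 4 is expected to give about 800 ng.h/mL in this assay, likely between 200 ng.h/mL and 3000 ng.h/mL.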

Compound 4, area under the concentration-time curve: 355 ng.h/mL
For compound 4 the middle estimate is 2.3-fold (0.35 log units) above the measured one, and the stated range covers the measured number.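

No new step can be read from this result: compound 3 stands without a number in this assay, and compound 1 differs from compound 4 in more than one place. The compounds shown leave open how the 3-hydroxypyrrolidin-1-yl group compares with the other groups at this place on the shared core. Nothing shown here explains the value of compound 4.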